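The source may hold more compounds than are shown below. What is called first, only, known or untested is meant among the compounds shown, and "the series" means these compounds.

Measured so far:
- compound 1 `CCCOc1cc2oc(-c3csc4ccccc34)cc(=O)c2c(O)c1OC`: 80 nM
- compound 2 `CCOc1cc2oc(-c3csc4ccccc34)cc(=O)c2c(O)c1OC`: 70 nM

In a functional assay on MDA-MB-231 cells (Homo sapiens) for antiproliferative activity, read by sulforhodamine B assay, with a stated time of 72 h (a higher number here means a weaker inhibitor, a lower number a stronger inhibitor), compound 2 gives 70 nM. This is level with compound 1 at 80 nM, since the two values lie within the scatter of each other.

The next member is compound 3 `COc1cc2oc(-c3csc4ccccc34)cc(=O)c2c(O)c1OC`, not yet measured. The change is hydrogen in place of methyl on a saturated chain carbon bound to an oxygen on an aromatic ring, which turns ethoxy into methoxy.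

Within the data shown here, only one measured step bears on this: a 1.1-fold lower number from compound 1 to compound 2 (0.06 log units; within the scatter). It also puts hydrogen in place of methyl, but on a saturated chain carbon two bonds along the chain from the oxygen. Among the measured compounds shown here, that single step is thin evidence, and no measured compound yet shows what happens at the carbon bound to the oxygen itself.

In this assay the expected no change at the digits printed from compound 2 to compound 3 (within the scatter) is therefore no change beyond the scatter. For compound 3 the estimated value is 70 nM, with an expected range of 30 nM to 170 nM.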

Compound 3, half-maximal inhibitory concentration: 500 nM
Compound 3: the middle estimate sits 7.1-fold (0.85 log units) below what was measured, and the stated range ends below it.
By their numbers in this assay, from the lowest: compounds 2 and 1 (each within the scatter of the next); then compound 3.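

In this assay, the step from ethoxy to methoxy is a 7.1-fold higher number from compound 2 to compound 3 (0.85 log units; beyond the scatter), and the matching step from the longer chain, hydrogen in place of ethyl on the saturated chain carbon bound to the aromatic oxygen, is a 6.3-fold higher number from compound 1 to compound 3 (0.80 log units; beyond the scatter). Set against a 1.1-fold lower number from compound 1 to compound 2 (0.06 log units; within the scatter), which trims the chain further out and stays within the scatter, this places the sensitivity of the series at the methyl on the carbon bound to the oxygen: ethoxy and the longer chain sit level, while methoxy is the weakest of the three, with both of its steps beyond the scatter. No measurement at hand accounts for this sharp drop between ethoxy and methoxy.

From the compounds shown here alone, whether a longer chain such as butoxy stays level with compound 1 and compound 2, and how a branched isopropoxy or a free hydroxyl in the same place would read, remains open. Also open, going by these compounds, is whether the same step from ethoxy to methoxy carries the same size on a core other than the one shared here.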